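Aryloxy core substitution: isopropoxy to morpholinylcarbonyl

The compounds below may be only part of what the source reports. "The series", "measured", "known", "first", "only" and "open" are said of these compounds alone.

Compound 3 `CC#C[C@@H](CC(=O)O)c1ccc(OC[C@H]2COc3ccc(OC(C)C)cc3O2)cc1` gives 280 nM in a functional assay on HEK293 cells for agonist activity at Free fatty acid receptor 1 (Homo sapiens), read by fluorescence and calcium flux, with a stated time of 10 min (a lower number here means that less compound is needed, a higher number that more compound is needed for the effect), the second highest of the three numbers: compound 1 `O=C(O)CCc1ccc(OCC2COc3ccc(Cl)cc3O2)cc1F` gives 830 nM, and compound 2 `CC#C[C@@H](CC(=O)O)c1ccc(OC[C@H]2COc3ccccc3O2)cc1` gives 90 nM. Compound 4 `CC#C[C@@H](CC(=O)O)c1ccc(OC[C@H]2COc3ccc(C(=O)N4CCOCC4)cc3O2)cc1` differs from compound 3 by (morpholin-4-yl)carbonyl in place of isopropoxy on an aromatic carbon. Among the measured compounds shown here, the one step that bears on this position, a 3.1-fold higher number from compound 2 to compound 3 (0.49 log units; beyond the scatter), shows that placing a substituent there raised the number modestly; compound 4 carries a larger group at the same carbon, and no measured pair shows what exchanging one substituent for another does there. A further modest rise, or no change beyond the scatter, is expected, as a 1.6-fold higher number from compound 3 to compound 4 (0.21 log units; within the scatter). Compound 4 is therefore estimated at 450 nM, within 150 nM to 1400 nM.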

Compound 4, half-maximal effective concentration: > 50000 nM
Compound 4: a limit, no number; the forecaster's own chance of this, stated with the estimate: 5%; middle value at least 110-fold (2.04 log units) from the limit.
By their numbers in this assay, from the lowest: compound 2; then compound 3; then compound 1. At a limit, above all of these: compound 4.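

In this assay, compound 4 stands at a limit and not at a number: the limit of > 50000 nM in this assay, at which 1 of the 4 values shown sits. This position therefore does not accept every substituent: (morpholin-4-yl)carbonyl in place of isopropoxy gives an at least 170-fold higher number from compound 3 to compound 4 (2.25 log units; beyond the scatter). Measured against hydrogen, the same group gives an at least 550-fold higher number from compound 2 to compound 4 (2.74 log units; beyond the scatter), a large step where isopropoxy gave only the modest 3.1-fold higher number from compound 2 to compound 3 (0.49 log units; beyond the scatter).

As far as these compounds go, whether this step goes with the carbonyl or with the ring remains open. A primary amide, a methoxy group or a piperidinylcarbonyl group on this carbon would bear on that question.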